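The compounds below may be only part of what the source reports. "The series", "measured", "known", "first", "only" and "open" are said of these compounds alone.

Working notes on the series.

In a functional assay on MCF7 cells (Homo sapiens) for antiproliferative activity, read by MTT assay, with a stated time of 72 h (a lower number here means a stronger inhibitor, a higher number a weaker inhibitor), compound 1 `Cc1cc(NCCN(C)C)nc2ccc(NC(=O)c3ccc(Cl)c(Cl)c3)cc12` gives 2550 nM. Among the measured compounds shown here, the only other measured member, compound 2 `CCN1CCN(c2cc(C)c3cc(NC(=O)c4ccc(Cl)cc4)ccc3n2)CC1`, gives 1530 nM in this assay; the two numbers lie within the usual scatter of each other, so neither compound is set apart from the other on the data in hand. For the measured compounds named here, no stepwise pair of measured compounds that differ in a single place is available, so no measured single-point step can be quoted.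

Compound 3 `Cc1cc(NCCN2CCCC2)nc2ccc(NC(=O)c3ccc(Cl)c(Cl)c3)cc12` is not yet measured. It differs from compound 1 in one place: pyrrolidin-1-yl in place of dimethylamino on a saturated chain carbon, two bonds along the chain from a nitrogen on an aromatic ring. Both groups carry one hydrogen-bond acceptor and no donor, and the change sits at the end of the chain away from the shared core of compound 1, which is kept intact.

With no measured step of this kind in the series, the expectation for compound 3 rests on compound 1 at 2550 nM alone: the step from compound 1 to compound 3 is estimated at a 1.3-fold lower number from compound 1 to compound 3 (0.11 log units; within the scatter), that is, no shift beyond the scatter in either direction. Compound 3 is therefore expected to give about 2000 nM in this assay, with a range of 800 nM to 5000 nM.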

Compound 3, half-maximal inhibitory concentration in the MCF7 assay: 1280 nM
For compound 3 the middle estimate is 1.6-fold (0.19 log units) above the measured one, and the stated range covers the measured number.
By their numbers in the MCF7 assay, from the lowest: compounds 3, 2 and 1 (each within the scatter of the next).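

Among the compounds shown here, this is the first measured single-point step at this position. In the MCF7 assay, pyrrolidin-1-yl in place of dimethylamino on a saturated chain carbon, two bonds along the chain from a nitrogen on an aromatic ring, gives a 2.0-fold lower number from compound 1 to compound 3 (0.30 log units; within the scatter), so closing the two methyl groups of the end group into a five-membered ring does not carry this pair beyond the scatter. In a physicochemical assay for solubility (a higher number here means a more soluble compound, a lower number a less soluble compound), compound 1 gives 122 ug/mL and compound 3 gives 84.5 ug/mL, which reads as a 1.4-fold lower number from compound 1 to compound 3 (0.16 log units; within the scatter). Neither read-out therefore sets compound 3 apart from compound 1, and nothing on hand bears on the reason for either step.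

The compounds shown leave open whether a different end group on this chain, such as morpholin-4-yl, a primary amine or a carboxylic acid, would move the number in the MCF7 assay beyond the scatter. They also leave open what a longer chain between the core and the end group would do in either read-out, and whether this exchange gives a similar step on a different core.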